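Swapping a formyl-methylphenyl biaryl arm for a pyridine

The source may report more compounds than this note shows. Statements on the series, on what has been measured and on what is new or still open speak of the compounds shown alone.

Measured compounds:
compound 1 `COc1ccc(C(=O)Nc2ccc(-c3ccc(-c4noc(C)n4)cc3C)cc2)cc1N1CCN(C)CC1` gives 8.2
compound 2 `COc1ccc(NC(=O)c2ccc(-c3ccc(C(=O)N(C)C)cc3C)cc2)cc1N1CCN(C)CC1` gives 9.2
compound 3 `COc1ccc(C(=O)Nc2ccc(-c3ccc(C=O)cc3C)cc2)cc1CCCN(C)C` gives 8.4

In a functional assay (Saphenous vein) with Canis familiaris (Canis lupus familiaris) as the target (on this read-out higher numbers stand for higher potency (the scale is a negative logarithm) and lower numbers for lower potency), compound 3 holds the second highest of the three numbers. Its value sits close to that of compound 1, a gap that stays within the scatter, so no order between compound 3 and compound 1 can be claimed. Compound 2 stands clearly higher, by a gap beyond the scatter.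

Compound 4 `COc1ccc(C(=O)Nc2ccc(-c3ccncc3)cc2)cc1CCCN(C)C` is not yet measured. Compared with compound 3 the change is pyridin-4-yl in place of 4-formyl-2-methylphenyl on an aromatic carbon. The leaving group is the larger one; the entering pyridin-4-yl keeps one hydrogen-bond acceptor but brings fewer heavy atoms and no second ring substituent, at the position para to a large group.

Within the data shown here, no single-change step between measured compounds exists to anchor this swap. Given that the two compounds with the highest values in this assay, compound 2 and compound 3, both carry a substituted aryl ring at this position, a downward step beyond the scatter is expected for compound 4, amounting to a number 0.90 log units lower from compound 3 to compound 4 (beyond the scatter). The estimate for compound 4 in this assay is 7.5, expected to lie between 6.7 and 8.3.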

Compound 4, negative logarithm of the antagonist equilibrium constant: 7.8
Beside the measured number, compound 4's estimate is 0.30 log units below it; the measured number falls inside the stated range.
By their numbers in this assay, from the lowest: compound 4; then compounds 1 and 3 (each within the scatter of the next); then compound 2.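

Among these compounds, this is the first single-change step at this position: in this assay, putting pyridin-4-yl in place of 4-formyl-2-methylphenyl gives a number 0.60 log units lower from compound 3 to compound 4 (beyond the scatter) on this aromatic carbon. The group here therefore affects potency, and the size of the step lies beyond the scatter. Even with 6 heavy atoms in place of 9, compound 4 still reaches 7.8 in this read-out, so the formyl and methyl groups are not needed for measurable antagonism, though no measurement here explains the step.

The change alters the ring, the formyl group and the methyl group together, so the compounds shown cannot assign the step to any one of them. On these data alone, how an unsubstituted phenyl ring, or a phenyl ring carrying only a methyl or only a formyl group, would compare at this position remains open.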